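The source may report more compounds than this note shows. Statements on the series, on what has been measured and on what is new or still open speak of the compounds shown alone.

Compound 2 `CCCCNc1nc(N)nc2ccn(Cc3ccccn3)c12` stands at the limit of the assay in an ADME assay on HEK293 cells (Homo sapiens) for cytotoxicity, read by ATP content, with a stated time of 6 h (on this read-out lower numbers stand for higher toxicity in this test and higher numbers for lower toxicity in this test), where compound 2 gives > 24000 nM. Compound 1 `CCCCNc1nc(N)nc2ccn(Cc3ccsc3)c12` likewise reaches only a limit, giving > 24000 nM in this assay. Compound 3 `CCCCNc1nc(N)nc2ccn(Cc3ccncc3)c12` also sits at a limit, with > 24000 nM. The steps a step that the two limits leave unreadable from compound 1 to compound 2, a step that the two limits leave unreadable from compound 1 to compound 3 and a step that the two limits leave unreadable from compound 2 to compound 3 therefore cannot be sized, since (the limit of > 24000 nM in this assay, at which 3 of the 3 values shown sit). Compound 4 `Cc1cnc(CNc2nc(N)nc3ccn(Cc4ccccn4)c23)o1` differs from compound 2 as 5-methyl-1,3-oxazol-2-yl in place of propyl on a saturated chain carbon bound to a nitrogen on an aromatic ring. Going by the values given here, none of the measured steps touches the butylamino side chain, so no measured step bears on this change; the expected step of a number no higher from compound 2 to compound 4 (the limit leaves the size open) in this assay rests on the series staying at the limit. Compound 4 is estimated at 24000 nM, with a range from 10000 nM to 24000 nM, most likely again reported only as a limit.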

Compound 4, half-maximal cytotoxic concentration: > 24000 nM
Compound 4: no number, only a limit (the forecaster's own chance of this, stated with the estimate: 80%); the middle value sits exactly at the limit.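

No new step can be read between compound 2 and compound 4 in this assay, as both stand only at a limit: the limit of > 24000 nM in this assay, at which 4 of the 4 values shown sit.

The compounds shown leave open whether any of these changes shifts the half-maximal cytotoxic concentration at all.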